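The source may report more compounds than this note shows. Statements on the series, on what has been measured and on what is new or still open speak of the compounds shown alone.

Measured compounds in a physicochemical assay for solubility, in phosphate buffer, measured as kinetic solubility, with a stated time of 1 h, at pH 7.4; a lower number here means a less soluble compound, a higher number a more soluble compound:
- compound 1, `COc1ccc2nc(C)cc(OCC(=O)Nc3cc(C)cc(C)c3)c2c1`: 26000 nM
- compound 2, `CSc1ccc2nc(C)cc(OCC(=O)Nc3cc(C)cc(C)c3)c2c1`: 3000 nM
- compound 3, `COc1ccc2nc(C)cc(OCC(=O)Nc3cc(C)c(OC)c(C)c3)c2c1`: 17000 nM

Compound 1 gives the highest of the three numbers in this assay. Compound 3 sits closest, the step of a 1.5-fold lower number from compound 1 to compound 3 (0.18 log units; within the scatter) lying within the scatter, so the two cannot be ordered. Compound 2 lies furthest away, with an 8.7-fold lower number from compound 1 to compound 2 (0.94 log units; beyond the scatter), a step beyond the scatter.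

Compound 4, `COc1ccc2nc(C)cc(OCC(=O)Nc3cc(F)cc(F)c3)c2c1`, is yet to be measured in this assay. It differs from compound 1 in one place: 3,5-difluorophenyl in place of 3,5-dimethylphenyl on an amide-type nitrogen

Neither measured step bears directly on this change. Both concern the shared core, one at the methoxy and one on the aryl amide ring of compound 3, whereas the change to compound 4 exchanges the whole aryl group on the amide-type nitrogen. The step from compound 1 to compound 3, also on that aryl group, stayed within the scatter; the step from compound 1 to compound 2 was modest but beyond it. Among the compounds with values here, with no direct precedent, the expectation for compound 4 is a step of a 1.2-fold higher number from compound 1 to compound 4 (0.06 log units; within the scatter) that stays within the scatter, with a wide range to cover either direction. Compound 4 is therefore estimated at 30000 nM, between 12000 nM and 75000 nM.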

Compound 4, solubility: 13000 nM
Compound 4: the middle estimate sits 2.3-fold (0.36 log units) above what was measured; the range from low to high includes it.
By their numbers in this assay, from the lowest: compound 2; then compounds 4, 3 and 1 (each within the scatter of the next).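

In this assay, 3,5-difluorophenyl in place of 3,5-dimethylphenyl on the amide-type nitrogen gives a 2.0-fold lower number from compound 1 to compound 4 (0.30 log units; within the scatter), so exchanging this whole aryl group leaves the two compounds unordered. Together with a 1.5-fold lower number from compound 1 to compound 3 (0.18 log units; within the scatter), this gives two changes on that aryl group that stay within the scatter, while an 8.7-fold lower number from compound 1 to compound 2 (0.94 log units; beyond the scatter), at the methoxy of the shared core, is the only step from compound 1 that lies beyond it. No measurement shown here offers an explanation for this result.

On these data alone, whether an amine or a carboxylic acid on this aryl group would produce a step beyond the scatter remains open. Also open, as far as these compounds go, is whether methylsulfanyl in place of methoxy would give a similar step with 3,5-difluorophenyl on the amide-type nitrogen.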